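This account rests on a few compounds, and the source may have more. Where it says the series, first, only, none or still open, it means among the compounds named here.

Measured so far:

- compound 1 `CN1CCN(c2ccc(C3=NN(S(=O)(=O)c4ccc(Br)cc4)C(c4ccc(N(C)C)cc4)C3)cc2)CC1`: 87.1%
- compound 2 `CN1CCN(c2ccc(C3=NN(S(=O)(=O)c4ccc(C(F)(F)F)cc4)C(c4ccc(N(C)C)cc4)C3)cc2)CC1`: 27%
- compound 3 `CN(C)c1ccc(C2CC(c3ccc(-n4cncn4)cc3)=NN2S(=O)(=O)c2ccc(Br)cc2)cc1`: 26.3%

All three were tested in a functional assay on HCC1806 cells (Homo sapiens) for inhibition, read by sulforhodamine B assay, tested at 10 uM; a higher number here means more inhibition at the concentration tested (going by the name of the read-out), a lower number less inhibition. Compound 1 gives 87.1% there. Compound 2 differs from compound 1 in one place: trifluoromethyl in place of bromo on an aromatic carbon. The step is a number 60.1 percentage points lower from compound 1 to compound 2 (beyond the scatter). Compound 3 is built on a different core than compound 1; the two cores differ as follows: 1H-1,2,4-triazol-1-yl in place of 4-methylpiperazin-1-yl on an aromatic carbon. That change also moves the read-out down, a number 60.8 percentage points lower from compound 1 to compound 3 (beyond the scatter). The values of compound 2 and compound 3 lie within the scatter of each other, so nothing separates them.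

Compound 4 `CN(C)c1ccc(C2CC(c3ccc(-n4cncn4)cc3)=NN2S(=O)(=O)c2ccc(C(F)(F)F)cc2)cc1` has not yet been measured in this assay. It differs from compound 3 in the same way that compound 2 differs from compound 1: trifluoromethyl in place of bromo on an aromatic carbon. The surroundings of the change are described identically in both pairs, so this is the same change on the other core. Made on compound 1, the change cost a number 60.1 percentage points lower from compound 1 to compound 2 (beyond the scatter); but compound 3 starts from 26.3%, and a read-out of inhibition cannot fall far below the low end of its scale. The step for compound 4 is therefore expected to be small, roughly a number 11.3 percentage points lower from compound 3 to compound 4 (beyond the scatter), because compound 3 already sits at 26.3% and little room remains downward. Compound 4 is thus estimated at 15%, with a range from 0% to 35%.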

Compound 4, a percentage reported as inhibition, at one concentration (the size of the read-out at that concentration, not a potency): 37%
Beside the measured number, compound 4's estimate is 22 percentage points below it; the whole stated range lies below it.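

Swapping bromo for trifluoromethyl in this assay does not carry over from one core to the other, since neither the size nor the direction of the step is kept: the same change on two cores in this assay, a number 60.1 percentage points lower (beyond the scatter) from compound 1 to compound 2 and a number 10.7 percentage points higher (beyond the scatter) from compound 3 to compound 4, 70.8 percentage points apart, beyond the scatter of two such steps.

Read the other way round, replacing 4-methylpiperazin-1-yl with 1H-1,2,4-triazol-1-yl is a large loss when bromo is present, whereas with trifluoromethyl present the step is a number 10 percentage points higher from compound 2 to compound 4 (within the scatter), so this change does not transfer either: the same change on two cores in this assay, a number 60.8 percentage points lower (beyond the scatter) from compound 1 to compound 3 and a number 10 percentage points higher (within the scatter) from compound 2 to compound 4, 70.8 percentage points apart, beyond the scatter of two such steps.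

The four compounds show that the two changes do not act independently here, as the high reading belongs only to the combination of bromo and 4-methylpiperazin-1-yl in compound 1 (87.1%), and the step of a number 10.7 percentage points higher from compound 3 to compound 4 (beyond the scatter) is modest by comparison, but with one set of four compounds they do not show why the groups depend on each other or whether the same holds for other groups.

On these data alone, whether a chloro or a methyl group in the place of bromo, or a morpholine in the place of 4-methylpiperazin-1-yl, would keep the high reading of compound 1 stays open. A reading at one concentration also leaves open how potent each compound is.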